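This account rests on a few compounds, and the source may have more. Where it says the series, first, only, none or still open, it means among the compounds named here.

Measured compounds in a functional assay for inhibition of sodium/hydrogen exchanger (Oryctolagus cuniculus); on this read-out lower numbers stand for stronger inhibition and higher numbers for weaker inhibition:
- compound 1, `Cc1cc(-c2ccco2)c(S(C)(=O)=O)cc1C(=O)N=C(N)N`: compound 1 gives 16 nM
- compound 2, `CSc1cc(C)c(C(=O)N=C(N)N)cc1S(C)(=O)=O`: compound 2 gives 6 nM
- compound 3, `Cc1cc(OC2CCCCC2)c(S(C)(=O)=O)cc1C(=O)N=C(N)N`: compound 3 gives 37 nM

Compound 3 holds the highest number of the three in this assay. Its nearest neighbour is compound 1, at a 2.3-fold higher number from compound 1 to compound 3 (0.36 log units; beyond the scatter); furthest is compound 2, at a 6.2-fold higher number from compound 2 to compound 3 (0.79 log units; beyond the scatter). Both of these steps describe the same position and show that cyclohexyloxy there gives a higher number than either furan-2-yl or methylsulfanyl.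

Compound 4, `Cc1cc(Nc2ccccc2)c(S(C)(=O)=O)cc1C(=O)N=C(N)N`, is the next in line. It differs from compound 3 as follows: anilino in place of cyclohexyloxy on an aromatic carbon. For the measured compounds named here, no measured pair covers anilino at this position, so the only guidance is indirect. The two steps into compound 3 both run to higher numbers, and the step of a 2.7-fold lower number from compound 1 to compound 2 (0.43 log units; beyond the scatter) shows that this position tolerates quite different groups within a modest span. Anilino carries an aromatic ring, as furan-2-yl in compound 1 does, whereas cyclohexyloxy in compound 3 carries a non-aromatic one. On that basis a modest move back toward lower numbers is expected for compound 4, roughly reversing the step seen into compound 3, with wide uncertainty.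

Compound 4 is estimated at 18 nM, within 6 nM to 60 nM, which means an expected step of a 2.1-fold lower number from compound 3 to compound 4 (0.31 log units; beyond the scatter).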

Compound 4, half-maximal inhibitory concentration: 21 nM
For compound 4 the middle estimate is 1.2-fold (0.07 log units) below the measured one; measured number inside the range.
By their numbers in this assay, from the lowest: compound 2; then compounds 1, 4 and 3 (each within the scatter of the next, the first and the last beyond it).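

In this assay, replacing cyclohexyloxy with anilino swaps a six-membered non-aromatic ring for an aromatic one and brings in a hydrogen-bond donor, yet the step stays within the scatter (a 1.8-fold lower number from compound 3 to compound 4 (0.25 log units; within the scatter)), as does the step from furan-2-yl to anilino (a 1.3-fold higher number from compound 1 to compound 4 (0.12 log units; within the scatter)), so anilino cannot be separated from either group on this read-out, even though compound 1 and compound 3 stand apart from each other. For the compounds shown here, only the step from methylsulfanyl clears the scatter (a 3.5-fold higher number from compound 2 to compound 4 (0.54 log units; beyond the scatter)), which leaves compound 2 alone at the low end of the four and shows that the two ring-bearing groups of 7 heavy atoms, cyclohexyloxy and anilino, do not match it here. No measurement at hand accounts for any of these steps.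

Still open, from the compounds shown here alone, is whether the hydrogen on the anilino nitrogen matters, which N-methylanilino would test directly, and whether a chlorine or a carboxylic acid on the anilino ring would move the number at all. Going by these compounds, it is equally open whether other small groups, such as methoxy or dimethylamino, would stay as low as methylsulfanyl or whether that group is a special case.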